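From a carboxy to a sulfomethyl at the amide end

A few compounds are considered here, and "the series" means these few. Any claim that something is new, unique, unknown or untested is made for them only; others in the source may bear on it.

Three compounds share one core and carry different acidic groups on its far side. Compound 1 `O=C(O)CNC(=O)c1ccc(C2CC2c2ccc(OCc3c(-c4c(Cl)cccc4Cl)noc3C3CC3)cc2Cl)cc1` reaches 58% in an assay on HEK293 cells for agonist activity at Bile acid receptor (Homo sapiens); a higher number here means a larger maximal response, a lower number a smaller maximal response. Compound 2 `O=C(O)c1cccc(N2CC(O)(c3ccc(OCc4c(-c5c(Cl)cccc5Cl)noc4C4CC4)cc3Cl)C2)c1` gives 94% in this assay, and compound 3 `CC(C)n1nc(C(=O)O)cc1C1CC1c1ccc(OCc2c(-c3c(Cl)cccc3Cl)noc2C2CC2)cc1Cl` gives 81% in this assay. Compound 1 therefore stands lowest of the three, below compound 3 by a gap that is beyond the scatter and further still below compound 2. No two of the measured compounds differ from each other in a single place, so no single structural change can yet be tied to a change in maximal response.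

Within the data shown here, compound 4 `O=C(NCCS(=O)(=O)O)c1ccc(C2CC2c2ccc(OCc3c(-c4c(Cl)cccc4Cl)noc3C3CC3)cc2Cl)cc1` is the one new compound, and it does differ from compound 1 in one place: sulfomethyl in place of carboxy on a saturated chain carbon bound to an amide-type nitrogen. The acid is kept but moved one chain position outward and changed in kind. Among the measured compounds shown here, with no measured step of this sort to lean on, only a small change in this assay is expected for compound 4, and whether it leans up or down cannot be told from these three numbers; the expected step from compound 1 to compound 4 is a number 4 percentage points higher from compound 1 to compound 4 (within the scatter), within the scatter. Compound 4 is thus estimated to reach 62%, with a likely range from 45% to 80%.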

Compound 4, largest response reached (reported as efficacy), in percent of the reference or control that the assay uses: 34%
The estimate for compound 4 lay 28 percentage points above the measured number, and the stated range ends above it.
By their numbers in this assay, from the lowest: compound 4; then compound 1; then compound 3; then compound 2.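

Replacing carboxy with sulfomethyl on a saturated chain carbon bound to an amide-type nitrogen gives the only single-place comparison among these compounds, and in this assay the result is a number 24 percentage points lower from compound 1 to compound 4 (beyond the scatter). This shows that the maximal response is sensitive to the group at this outer end of the amide side chain, even though the shared core and the amide stay the same. Read in full, the change is (carboxymethyl)carbamoyl to (2-sulfoethyl)carbamoyl, so the chain and its end group change together, and no data shown here explain why the response falls.

The compounds shown leave open whether the drop follows from the longer chain or from the sulfur-containing end group, a question that a 2-carboxyethyl group at this place, keeping the carboxylic acid on the longer chain, would help to separate. They also leave open whether a phosphonic acid or a tetrazole at the chain end would fall closer to compound 1 or to compound 4.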